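Removing the Acid From a Short Ether Chain

A few compounds are considered here, and "the series" means these few. Any claim that something is new, unique, unknown or untested is made for them only; others in the source may bear on it.

Compound 3 `O=C(O)COc1ccc2c(=O)c(-c3ccc(O)cc3)coc2c1` carries a carboxy on its ether chain. In an assay (Cricetulus griseus) for inhibition of aldehyde dehydrogenase, mitochondrial (Homo sapiens) (on this read-out lower numbers stand for stronger inhibition and higher numbers for weaker inhibition), compound 3 gives 1200 nM, the highest of the two plain numbers here. Compound 1 `O=C(O)CCCCCCCCCOc1ccc2c(=O)c(-c3ccc(O)cc3)coc2c1`, whose carboxy sits nine bonds along the chain from an oxygen on an aromatic ring, gives 50 nM in this assay. Compound 2 `CCCCCCCCCCCCOc1ccc2c(=O)c(-c3ccc(O)cc3)coc2c1`, whose chain ends in propyl rather than carboxy, gives only a limit of this assay, > 9000 nM. Going by the values given here, that one step, an at least 180-fold higher number from compound 1 to compound 2 (2.25 log units; beyond the scatter), is the sole guide for the change now made. Compound 4 `CCOc1ccc2c(=O)c(-c3ccc(O)cc3)coc2c1` differs from compound 3 by methyl in place of carboxy on a saturated chain carbon bound to an oxygen on an aromatic ring. Losing the carboxy is expected to weaken inhibition by a large step, a 13-fold higher number from compound 3 to compound 4 (1.10 log units; beyond the scatter). Compound 4 is therefore estimated at 15000 nM, between 4000 nM and 60000 nM, quite possibly beyond what this assay can report.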

Compound 4, half-maximal inhibitory concentration: 80 nM
Estimate against measurement, compound 4: 190-fold (2.27 log units) above; the measured number lies below the stated range.
By their numbers in this assay, from the lowest: compounds 1 and 4 (each within the scatter of the next); then compound 3. At a limit, above all of these: compound 2.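

On this short ether chain the carboxy is not needed: trading it for methyl gives a 15-fold lower number from compound 3 to compound 4 (1.18 log units; beyond the scatter), the opposite direction from the long chain, where losing the carboxy gave an at least 180-fold higher number from compound 1 to compound 2 (2.25 log units; beyond the scatter). Ethoxy without any carboxy matches the long acid, with a 1.6-fold higher number from compound 1 to compound 4 (0.20 log units; within the scatter), and shortening the chain that lacks a carboxy gives an at least 110-fold lower number from compound 2 to compound 4 (2.05 log units; beyond the scatter). That last step starts from a limit, not a number, for compound 2: the limit of > 9000 nM in this assay, at which 1 of the 4 values shown sits.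

As far as these compounds go, how a mid-length chain would behave, ending in methyl or in a carboxylic acid, stays open. So does whether an amine at the chain end would act like the carboxy.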